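Cyclopentylcarbamoyl in place of fluoro on compound 2

The source may report more compounds than this note shows. Statements on the series, on what has been measured and on what is new or still open speak of the compounds shown alone.

Compound 2 `CCC1C(=O)N(C)c2cnc(-n3ccc4cc(F)ccc43)nc2N1c1ccn(C)n1` gives 1500 nM in an assay for inhibition of serine/threonine-protein kinase PLK2 (Homo sapiens), read by FRET and Z'-LYTE, with a stated time of 1 h (on this read-out lower numbers stand for stronger inhibition and higher numbers for weaker inhibition), the highest of the three numbers measured. Compound 1 `CC[C@@H]1C(=O)N(C)c2cnc(Nc3ccc(S(=O)(=O)NCCCO)cc3)nc2N1C1CCCC1` gives 8.16 nM and compound 3 `CC[C@@H]1C(=O)N(C)c2cnc(Nc3ccc(S(=O)(=O)NC4CCCC4)cc3)nc2N1C1CCCC1` gives 23.9 nM; both differ from compound 2 in more than one place. Among the compounds with values here, the only single-point step on record, a 2.9-fold higher number from compound 1 to compound 3 (0.47 log units; beyond the scatter), concerns a substituent on a sulfonamide nitrogen and bears only loosely on the present change. Compound 4 `CCC1C(=O)N(C)c2cnc(-n3ccc4cc(C(=O)NC5CCCC5)ccc43)nc2N1c1ccn(C)n1` differs from compound 2 by cyclopentylcarbamoyl in place of fluoro on an aromatic carbon. Within the data shown here, no measured pair tracks this replacement directly, so the expectation is wide: a modest step toward stronger inhibition is expected, a 2.5-fold lower number from compound 2 to compound 4 (0.40 log units; beyond the scatter). Compound 4 is accordingly estimated at 600 nM, with a range from 150 nM to 3000 nM.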

Compound 4, half-maximal inhibitory concentration: 90.9 nM
Estimate against measurement, compound 4: 6.6-fold (0.82 log units) above; the whole stated range lies above it.
By their numbers in this assay, from the lowest: compound 1; then compound 3; then compound 4; then compound 2.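

In this assay this aromatic carbon, meta to a fused ring and para to a fused ring, accepts far more than fluoro: cyclopentylcarbamoyl gives a 17-fold lower number from compound 2 to compound 4 (1.22 log units; beyond the scatter) and counts as a large step. The change adds a five-membered non-aromatic ring, a hydrogen-bond donor and a hydrogen-bond acceptor, and inhibition strengthens with them. No evidence here bears on the reason for this step.

Which part of the group carries the step stays open. A methyl amide, a dimethyl amide or a carboxylic acid at this carbon would help separate the amide from the cyclopentyl ring.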